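This account rests on a few compounds, and the source may have more. Where it says the series, first, only, none or still open, it means among the compounds named here.

Compound 1 `CN(O)C(=O)c1cc2ccn(Cc3ccc(F)cc3)c2cn1`: 135000 nM
Compound 2 `CN1CCN(Cc2cn(Cc3ccc(F)cc3)c3cnc(C(=O)N(C)O)cc23)CC1`: > 224000 nM

Both compounds were tested in an ADME assay on CEM-SS cells (Homo sapiens) for cytotoxicity, read by XTT assay; on this read-out lower numbers stand for higher toxicity in this test and higher numbers for lower toxicity in this test. Compound 2 gives > 224000 nM, and this is a limit of the assay, not a number. the limit of > 224000 nM in this assay, at which 1 of the 2 values shown sits, is therefore where compound 2 stands, so any comparison with it is only approximate.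

Compound 3 `CN(O)C(=O)c1cc2c(CN3CCNC(=O)C3)cn(Cc3ccc(F)cc3)c2cn1` keeps the shared core and differs from compound 2 in one place, with 3-oxopiperazin-1-yl in place of 4-methylpiperazin-1-yl on a saturated chain carbon bound to an aromatic carbon. Read one bond further out, this is (4-methylpiperazin-1-yl)methyl to (3-oxopiperazin-1-yl)methyl.

Among the measured compounds shown here, no measured step covers this swap directly. The nearest guide is an at least 1.6-fold higher number from compound 1 to compound 2 (0.21 log units; that floor lies within the scatter), which came from adding the whole (4-methylpiperazin-1-yl)methyl group in place of hydrogen on an aromatic carbon. Since that larger change gave a step of only this size, a swap within the group is expected to give no step beyond the scatter in this assay. The expected change is an at least 1.0-fold lower number from compound 2 to compound 3 (0.00 log units; that floor lies within the scatter). For compound 3 the estimated value is 220000 nM, with an expected range of 110000 nM to 450000 nM.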

Compound 3, half-maximal cytotoxic concentration: > 100000 nM
Compound 3 was reported as a limit (the forecaster's own chance of this, stated with the estimate: 55%); the middle value is on the limit's open side.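

Compound 2 and compound 3 are both reported only as limits in this assay, so no step can be read between them, nor from compound 1 to compound 3. The compounds shown leave open whether 3-oxopiperazin-1-yl in place of 4-methylpiperazin-1-yl changes the number in this assay at all, and in which direction.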